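A few compounds are considered here, and "the series" means these few. Any claim that something is new, unique, unknown or untested is made for them only; others in the source may bear on it.

Measured in a functional assay on HepG2 cells (Homo sapiens) for antiproliferative activity, read by MTT assay; on this read-out lower numbers stand for stronger inhibition and higher numbers for weaker inhibition:
- compound 1 `CCNC(=O)c1oc2nc(-c3ccccc3)cc(C(F)(F)F)c2c1N`: 42800 nM
- compound 2 `Nc1c(C(=O)N/N=C/c2ccc(Br)cc2)oc2nc(-c3cccs3)cc(C(F)(F)F)c12`: 6100 nM
- compound 3 `CCCNC(=O)c1oc2nc(-c3ccccc3)cc(C(F)(F)F)c2c1N`: 37400 nM

Compound 2 gives the lowest number of the three, and its distance from each of the other two lies beyond the scatter. Compound 4 `Nc1c(C(=O)NC2CCCC2)oc2nc(-c3cccs3)cc(C(F)(F)F)c12` differs from it in one place: a group of 5 heavy atoms (5 carbon; one five-membered non-aromatic ring of carbon only) in place of a group of 9 heavy atoms (7 carbon, 1 nitrogen, 1 bromine; one six-membered aromatic ring of carbon only), on an amide-type nitrogen. Among the compounds with values here, no measured step covers this exchange. The only one, a 1.1-fold lower number from compound 1 to compound 3 (0.06 log units; within the scatter), is a small change on a saturated chain and offers little guidance for a change of this kind. Compound 1 and compound 3 are the nearest comparison, since each also has a saturated carbon group on the amide-type nitrogen, although the core of compound 1 is not that of compound 4. Compound 1 gives 42800 nM and compound 3 gives 37400 nM, so compound 4 is expected to move toward them, though perhaps not all the way. The step expected in this assay is therefore a 3.3-fold higher number from compound 2 to compound 4 (0.52 log units; beyond the scatter). For compound 4 the estimated value is 20000 nM, with an expected range from 7000 nM to 50000 nM.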

Compound 4, half-maximal inhibitory concentration: 20800 nM
Beside the measured number, compound 4's estimate is 1.0-fold (0.02 log units) below it; the measured number falls inside the stated range.
By their numbers in this assay, from the lowest: compound 2; then compounds 4, 3 and 1 (each within the scatter of the next, the first and the last beyond it).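

Within the data shown here, with the shared core held constant, the exchange on the amide-type nitrogen gives a 3.4-fold higher number from compound 2 to compound 4 (0.53 log units; beyond the scatter) in this assay and is a modest step beyond the scatter, while the only earlier step, a 1.1-fold lower number from compound 1 to compound 3 (0.06 log units; within the scatter), stayed within it. Among these compounds, this shows that the number can respond to what sits on this nitrogen, at least when cyclopentyl enters for the larger bromine-bearing aromatic group, although the single exchange changes the aromatic ring, the bromine, the double bond and the hydrogen-bond acceptor together and cannot separate them. Nothing available explains the size or direction of this step.

As far as these compounds go, whether a benzyl group or a morpholine ring on the same nitrogen would give a number nearer compound 2 or compound 4 remains open. From the compounds shown here alone, it is also open whether the same exchange would give a similar step on the core of compound 1.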